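Replacing the sulfanyl side group of compound 2

The source may report more compounds than this note shows. Statements on the series, on what has been measured and on what is new or still open speak of the compounds shown alone.

Measured so far:
Compound 1 `CCCCC1([C@@H](O)/C=C/C2[C@H](O)CC(=O)[C@@H]2CCCCCCC(=O)O)CCC1` gives 0.017 mg/kg 
Compound 2 `CCCCC1([C@H](O)/C=C/C2CCC(=O)[C@@H]2CCCCSCC(=O)OCC)CCC1` gives 0.03 mg/kg 

Both numbers come from a functional assay on the whole organism (strain Hartley) for inhibition, with Cavia porcellus as the target, with stated times of 15 min and 2 min (a lower number here means that less compound is needed, a higher number that more compound is needed for the effect), and they lie within the usual scatter of each other. Compound 2 therefore stands level with compound 1 on the numbers available, and neither can be called the better of the two.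

The next compound is compound 3 `CCCCC1([C@H](O)/C=C/C2CCC(=O)[C@@H]2CCCCCCC(=O)O)CCC1` and it differs from compound 2 in one place: 2-carboxyethyl in place of ((ethoxycarbonyl)methyl)sulfanyl on a saturated chain carbon, four bonds along the chain from a saturated ring carbon. Here 2-carboxyethyl stands in place of ((ethoxycarbonyl)methyl)sulfanyl on a saturated chain carbon, four bonds along the chain from a saturated ring carbon.

Going by the values given here, no measured pair shows this change on its own, so the data give no direct guide to its size or direction. With nothing to point either way, no shift beyond the scatter is expected in this assay and the range is kept wide on both sides. The expected step of a 1.1-fold lower number from compound 2 to compound 3 (0.03 log units; within the scatter) stays within the scatter. For compound 3 the estimated value is 0.028 mg/kg with 0.007 mg/kg to 0.11 mg/kg as the expected range.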

Compound 3, dose for half-maximal effect: 0.0024 mg/kg
For compound 3 the middle estimate is 12-fold (1.07 log units) above the measured one; the measured number lies below the stated range.
By their numbers in this assay, from the lowest: compound 3; then compounds 1 and 2 (each within the scatter of the next).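

In this assay, going by these compounds alone, this place on the chain proves sensitive to what stands there: with 2-carboxyethyl in place of ((ethoxycarbonyl)methyl)sulfanyl, the data show a 13-fold lower number from compound 2 to compound 3 (1.10 log units; beyond the scatter) and so give the first step that can be read, one well beyond the scatter. The swap bundles several differences, as the sulfur leaves, the ethyl ester gives way to a free carboxylic acid, and a hydrogen-bond donor enters, so the step belongs to the whole exchange and not to any single part of it. Nothing available accounts for why the number falls so far.

The compounds shown leave open which part of the exchange carries the step: a (carboxymethyl)sulfanyl group would keep the sulfur while freeing the acid, and a 2-(ethoxycarbonyl)ethyl group would drop the sulfur while keeping the ester. Either group, set on the same saturated chain carbon, would begin to pull the two differences apart, and whether the step from this exchange holds on another core also remains open.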